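Changing the ring-nitrogen substituent on a shared core

A few compounds are considered here, and "the series" means these few. Any claim that something is new, unique, unknown or untested is made for them only; others in the source may bear on it.

Of the compounds shown here, three sharing one core have been measured in an assay on HEK293 cells for agonist activity at Toll-like receptor 8 (Homo sapiens), read by a luciferase reporter, with a stated time of 6 h; a higher number here means that more compound is needed for the effect, a lower number that less compound is needed. Compound 1 `CCCCNc1nc(N)nc2c1CN(Cc1cccc(Cl)c1Cl)CC2` gives 0.18 uM in this assay. Compound 2 `CCCCNc1nc(N)nc2c1CN(Cc1cc(F)cc(F)c1)CC2` gives 0.23 uM, and a 1.3-fold higher number from compound 1 to compound 2 (0.11 log units; within the scatter). Compound 3 `CCCCNc1nc(N)nc2c1CN(Cc1ccco1)CC2` gives 0.08 uM, the lowest of the three numbers: the change from compound 1 is a 2.3-fold lower number from compound 1 to compound 3 (0.35 log units; beyond the scatter), and from compound 2 it is a 2.9-fold lower number from compound 2 to compound 3 (0.46 log units; beyond the scatter).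

Compound 4 `CCCCNc1nc(N)nc2c1CN(C(=O)c1scnc1C)CC2` has not been measured. It differs from compound 3 in one place: (4-methyl-1,3-thiazol-5-yl)carbonyl in place of (furan-2-yl)methyl on an amine nitrogen in a ring. The measured steps that bear on this change are those in which the group on the same ring nitrogen was exchanged, namely the step from compound 1 to compound 3 and the step from compound 2 to compound 3, both of modest size. For the measured compounds named here, the change to compound 4 is of a different kind, since a carbonyl now joins the ring to the ring nitrogen, and no measured pair shows such an exchange. The expectation is therefore uncertain, leaning toward a higher number, with a 6.3-fold higher number from compound 3 to compound 4 (0.80 log units; beyond the scatter) as the estimated step. On that basis compound 4 is expected to give about 0.5 uM in this assay, within a range from 0.12 uM to 2 uM.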

Compound 4, minimum effective concentration: 5.6 uM
Compound 4: middle estimate off by 11-fold (1.05 log units), on the low side; measured number above the stated range.
By their numbers in this assay, from the lowest: compound 3; then compounds 1 and 2 (each within the scatter of the next); then compound 4.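

In this assay, the step at this amine nitrogen in a ring is a 70-fold higher number from compound 3 to compound 4 (1.85 log units; beyond the scatter), far larger than the earlier exchanges, of which the largest is a 2.9-fold lower number from compound 2 to compound 3 (0.46 log units; beyond the scatter). Those earlier exchanges all kept a saturated chain carbon on the nitrogen and varied only the ring it carried, so they showed that this position accepts 2,3-dichlorophenyl, 3,5-difluorophenyl and furan-2-yl with modest differences, whereas the new result shows that the position is far from indifferent once (4-methyl-1,3-thiazol-5-yl)carbonyl stands there. For the compounds shown here, nothing available explains the size of this step, and the single exchange changes both the link and the ring at once, so the two contributions cannot be told apart.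

The compounds shown leave open whether the higher number follows the carbonyl or the 4-methyl-1,3-thiazol-5-yl ring, a question that (furan-2-yl)carbonyl and (4-methyl-1,3-thiazol-5-yl)methyl on the same nitrogen would separate. They also leave open how the shared core behaves with a plain hydrogen or a small acetyl group on that nitrogen.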